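Dropping the bromo group from compound 3

A few compounds are considered here, and "the series" means these few. Any claim that something is new, unique, unknown or untested is made for them only; others in the source may bear on it.

Values in a functional assay on HeLa cells (Homo sapiens) for antiproliferative activity, read by sulforhodamine B assay, with a stated time of 72 h; on this read-out lower numbers stand for stronger inhibition and higher numbers for weaker inhibition:
- compound 1 `NC(=S)N/N=C/c1ccc2ccccc2n1`: 960 nM
- compound 2 `Cc1ccccc1NC(=S)N/N=C/c1ccc2ccccc2n1`: > 100000 nM (a limit)
- compound 3 `S=C(N/N=C/c1ccc2ccccc2n1)Nc1ccccc1Br`: > 100000 nM (a limit)

Compound 3 stands only at a limit (> 100000 nM) and carries no number. That position is the limit of > 100000 nM in this assay, at which 2 of the 3 values shown sit, in this small series.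

Compound 4 `S=C(N/N=C/c1ccc2ccccc2n1)Nc1ccccc1` has hydrogen in place of bromo on an aromatic carbon, ortho to a large group, so that 2-bromophenyl becomes phenyl: hydrogen in place of bromo on an aromatic carbon.

Two large measured steps bear on this change. They are an at least 100-fold higher number from compound 1 to compound 2 (2.01 log units; beyond the scatter) and an at least 100-fold higher number from compound 1 to compound 3 (2.01 log units; beyond the scatter) and both lie beyond the scatter. In each, a substituted phenyl replaces hydrogen on an amide-type nitrogen. The remaining step, a step that the two limits leave unreadable from compound 2 to compound 3, gives no size for a change at this aromatic carbon.

Compound 4 keeps a phenyl on that nitrogen, so much of the rise seen in an at least 100-fold higher number from compound 1 to compound 3 (2.01 log units; beyond the scatter) is expected to persist. A modest shift toward a lower number is expected, and a second limit reading would not be surprising. The expected step is an at least 2.5-fold lower number from compound 3 to compound 4 (0.39 log units; beyond the scatter) in this assay as estimated here. For compound 4 the estimate is 40000 nM with an expected range of 4000 nM to 100000 nM in this read-out.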

Compound 4, half-maximal inhibitory concentration: 27400 nM
Estimate against measurement, compound 4: 1.5-fold (0.16 log units) above; low and high end bracket the measured number.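

In this assay, hydrogen in place of bromo on this aromatic carbon gives an at least 3.6-fold lower number from compound 3 to compound 4 (0.56 log units; beyond the scatter), and hydrogen in place of methyl on the same carbon gives an at least 3.6-fold lower number from compound 2 to compound 4 (0.56 log units; beyond the scatter). Both substituted compounds therefore lie further from compound 1 than the unsubstituted phenyl does, so the group on this carbon counts apart from the phenyl that carries it, and both sizes are lower bounds only. Phenyl in place of hydrogen on the amide-type nitrogen now has a readable size, a 29-fold higher number from compound 1 to compound 4 (1.46 log units; beyond the scatter), and this step ends on a number and not on the limit that closes the steps to compound 2 and compound 3: the limit of > 100000 nM in this assay, at which 2 of the 4 values shown sit.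

The step between compound 2 and compound 3 cannot be read, so bromo and methyl stay unranked against each other. As far as these compounds go, whether a methyl or a longer chain on that nitrogen would cost as much as phenyl stays open, as does whether an amine or a carboxylic acid on the phenyl would move the number back toward compound 1 at 960 nM.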